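The source may report more compounds than this note shows. Statements on the series, on what has been measured and on what is new or still open speak of the compounds shown alone.

Measured compounds in an ADME assay on Huh-7 cells (Homo sapiens) for cytotoxicity; a lower number here means a stronger inhibitor of growth, a higher number a weaker inhibitor of growth:

Compound 1, `COc1cc2c(=O)c(C(=O)c3ccc(C)cc3)cn(Cc3ccccc3)c2cc1OC`: "not active" (no number reported)
Compound 2, `COc1cc2c(=O)c(COCc3ccc(Cl)cc3)cn(Cc3ccccc3)c2cc1OC`: "not active" (no number reported)
Compound 3, `COc1cc2c(=O)c(C(=O)OCc3ccc(C)cc3)cn(Cc3ccc(C(F)(F)F)cc3F)c2cc1OC`: 20000 nM

Compound 1 gives no number in this assay; its result of "not active" (no number reported) is a statement of no measurable effect rather than a concentration. The same holds for compound 2, whose result in this assay is "not active" (no number reported). Only compound 3 gives a number in this assay, 20000 nM, which is weak. Within this small set, compound 1 therefore stands among the two entries without a value, and no step between any pair of these compounds is available to set a scale.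

The compound under consideration, compound 4, is `COc1cc2c(=O)c(C(=O)c3ccc(C)cc3)cn(Cc3ccc(N)cc3)c2cc1OC`. It differs from compound 1 in one place: amino in place of hydrogen on an aromatic carbon. The shared core and the rest of compound 1 stay as they are.

Among the measured compounds shown here, no step between measured compounds covers this change, so its size in this assay is open. Given that compound 1 shows "not active" (no number reported) in this assay, any effect of compound 4 is expected to be weak at best, and a result without a number is a real possibility. Compound 4 is expected to give about 40000 nM in this assay, within 10000 nM to 150000 nM.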

Compound 4, concentration for 50% growth inhibition: "not active" (no number reported)
No number was reported for compound 4, so the estimate cannot be set against anything.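

Among the compounds shown here, compound 1 at "not active" (no number reported) and compound 4 at "not active" (no number reported) leave no step readable in this assay for the change from phenyl to 4-aminophenyl. The compounds shown leave open whether this change shifts growth inhibition at all. No measured evidence bears on this result.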